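The source may report more compounds than this note shows. Statements on the series, on what has been measured and on what is new or still open speak of the compounds shown alone.

Measured so far in a functional assay on HeLa cells (Homo sapiens) for cytotoxicity, read by MTT assay, with a stated time of 24 h; a higher number here means a weaker inhibitor, a lower number a stronger inhibitor:

- compound 1 `C/C(=N\NC(=O)/C(C#N)=C/c1ccccc1)c1c(O)c2ccc(O)cc2oc1=O`: 15800 nM
- compound 2 `C/C(=N\NC(=O)/C(C#N)=C/c1ccc(O)cc1)c1c(O)c2ccc(O)cc2oc1=O`: 6020 nM
- compound 3 `COc1ccc(/C=C(\C#N)C(=O)N/N=C(\C)c2c(O)c3ccc(O)cc3oc2=O)cc1`: 7850 nM

The three compounds share one core and differ only in the substituent on the benzene ring of the side chain. Compound 3 stands second highest of the three numbers, but it cannot be separated from either neighbour: the data show a 2.0-fold lower number from compound 1 to compound 3 (0.30 log units; within the scatter) and a 1.3-fold higher number from compound 2 to compound 3 (0.12 log units; within the scatter). Only a 2.6-fold lower number from compound 1 to compound 2 (0.42 log units; beyond the scatter) exceeds the scatter, and that step is modest.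

The next compound is compound 4 `C/C(=N\NC(=O)/C(C#N)=C/c1ccc([N+](=O)[O-])cc1)c1c(O)c2ccc(O)cc2oc1=O`, which takes the series from 4-methoxyphenyl to 4-nitrophenyl, with nitro in place of methoxy on an aromatic carbon, para to a large group: nitro in place of methoxy on an aromatic carbon. For the measured compounds named here, no measured compound carries a nitro group, so the evidence is indirect. It rests on the three steps above, each of which changes the same position and none of which is large. A small step in this assay is therefore expected, with no direction favoured and probably nothing beyond the scatter. The expected step is a 1.0-fold higher number from compound 3 to compound 4 (0.01 log units; within the scatter). The estimate for compound 4 is 8000 nM, with an expected range from 3500 nM to 18000 nM.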

Compound 4, half-maximal inhibitory concentration: 8360 nM
Compound 4: middle estimate off by 1.0-fold (0.02 log units), on the low side, and the stated range covers the measured number.
By their numbers in this assay, from the lowest: compounds 2, 3, 4 and 1 (each within the scatter of the next, the first and the last beyond it).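

For the compounds shown here, the nitro group is the first substituent that does not carry oxygen directly on the ring, yet at this place, para to a large group, it gives a number that cannot be told apart from those of the two other substituted compounds in this assay: the data show a 1.1-fold higher number from compound 3 to compound 4 (0.03 log units; within the scatter) and a 1.4-fold higher number from compound 2 to compound 4 (0.14 log units; within the scatter). Replacing hydrogen with nitro also stays inside the noise, with a 1.9-fold lower number from compound 1 to compound 4 (0.28 log units; within the scatter), so compound 4 joins compound 3 in sitting within the scatter of the unsubstituted compound 1. Across hydroxy, methoxy and nitro, then, the identity of the group at this position makes no readable difference among the substituted compounds, and the only step beyond the scatter remains a 2.6-fold lower number from compound 1 to compound 2 (0.42 log units; beyond the scatter), which compound 3 and compound 4 do not reproduce.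

The compounds shown leave open whether an amine, a carboxylic acid or a longer chain at this same place would move the number beyond the scatter of these values. Nothing available explains why such different groups read so alike in this assay.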